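The compounds below may be only part of what the source reports. "The series", "measured", "known", "first", "only" and "open" are said of these compounds alone.

Series notes. Compound 1 `COc1ccc2c(/C=C/C(=O)c3cc(N)c(OC)c(OC)c3)c[nH]c2c1` gives 155 nM in a functional assay on HeLa cells (Homo sapiens) for antiproliferative activity, read by MTT assay, with a stated time of 48 h; a higher number here means a weaker inhibitor, a lower number a stronger inhibitor. Compound 2 `COc1ccc2c(/C=C/C(=O)c3cc(N)c(OC)c(OC)c3)cn(C)c2c1` gives 356 nM in this assay, and the step of a 2.3-fold lower number from compound 2 to compound 1 (0.36 log units; beyond the scatter) corresponds to hydrogen in place of methyl on an aromatic nitrogen. Compound 3 `COc1cc(C(=O)/C=C/c2cn(C)c3ccccc23)cc(N)c1OC` gives 668 nM in this assay; the step of a 1.9-fold higher number from compound 2 to compound 3 (0.27 log units; within the scatter) corresponds to hydrogen in place of methoxy on an aromatic carbon, so compounds 2 and 3 cannot be separated by these numbers, while compound 3 sits beyond the scatter from compound 1.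

Compound 4 `COc1cc(C(=O)/C=C/c2c[nH]c3ccccc23)cc(N)c1OC` is not yet measured. Relative to compound 3 the change is hydrogen in place of methyl on an aromatic nitrogen, the same change as that from compound 2 to compound 1, where it gave a 2.3-fold lower number from compound 2 to compound 1 (0.36 log units; beyond the scatter). The two cores differ by hydrogen in place of methoxy on an aromatic carbon; the change occurs twice in this set. For the measured compounds named here, on the single earlier example, a step of about the same size is expected from compound 3 to compound 4 in this assay, namely a 2.2-fold lower number from compound 3 to compound 4 (0.35 log units; beyond the scatter), resting on compound 2 at 356 nM and compound 1 at 155 nM. Going by the values given here, with only one precedent the range is kept wide. Compound 4 is thus estimated at 300 nM, between 150 nM and 650 nM.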

Compound 4, half-maximal inhibitory concentration: 529 nM
Estimate against measurement, compound 4: 1.8-fold (0.25 log units) below; the measured number falls inside the stated range.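

In this assay, hydrogen in place of methyl on the aromatic nitrogen gives a 1.3-fold lower number from compound 3 to compound 4 (0.10 log units; within the scatter), and hydrogen in place of methoxy on an aromatic carbon gives a 3.4-fold higher number from compound 1 to compound 4 (0.53 log units; beyond the scatter). Each change can now be read on two cores, and for the change on the aromatic nitrogen the two readings cannot be told apart, so the numbers are consistent with it carrying over from one core to the other: the same change on two cores in this assay, a 2.3-fold lower number (0.36 log units; beyond the scatter) from compound 2 to compound 1 and a 1.3-fold lower number (0.10 log units; within the scatter) from compound 3 to compound 4, 1.8-fold (0.26 log units) apart, within the scatter of two such steps The methoxy change reads the same way, although two pairs per change neither fix the size of either step nor show that it would carry over to any further core: the same change on two cores in this assay, a 1.9-fold higher number (0.27 log units; within the scatter) from compound 2 to compound 3 and a 3.4-fold higher number (0.53 log units; beyond the scatter) from compound 1 to compound 4, 1.8-fold (0.26 log units) apart, within the scatter of two such steps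

The compounds shown leave open how a larger group on the aromatic nitrogen, such as ethyl or a longer chain, would read in this assay. Also open, going by these compounds, is how a halogen such as fluorine or chlorine would read in place of the methoxy on the aromatic carbon, and how a hydroxyl would read in place of the amine.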